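The compounds below may be only part of what the source reports. "The series", "measured", "known", "first", "only" and "open" are said of these compounds alone.

Compound 2 `CC#CC(CC(=O)O)c1ccc(OCc2ccc(C(=O)N3CCN(c4cccc(F)c4)CC3)s2)cc1` gives, in a functional assay on HEK293 cells for agonist activity at Free fatty acid receptor 1 (Homo sapiens), read by fluorescence and calcium flux (on this read-out lower numbers stand for an effect already at smaller amounts and higher numbers for an effect only at larger amounts of compound), 97 nM, the lower of the two numbers shown so far: compound 1 `CC#CC(CC(=O)O)c1ccc(OCc2ccc(C(=O)N3CCN(c4ccc(OC)cc4)CC3)s2)cc1` gives 289 nM, and the step of a 3.0-fold lower number from compound 1 to compound 2 (0.47 log units; beyond the scatter) exchanged the whole group on the ring nitrogen. Compound 3 `CC#CC(CC(=O)O)c1ccc(OCc2ccc(C(=O)N3CCN(c4ccccc4F)CC3)s2)cc1` differs from compound 2 only by 2-fluorophenyl in place of 3-fluorophenyl on an amine nitrogen in a ring. Going by the values given here, no measured step shifts a fluorine from one position to another on that ring; the single step that touches this nitrogen swapped one group for a different one. The expected step of a 1.3-fold higher number from compound 2 to compound 3 (0.13 log units; within the scatter) is therefore small, within the usual scatter. Compound 3 is estimated at 130 nM in this assay, with a range from 50 nM to 350 nM.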

Compound 3, half-maximal effective concentration: 113 nM
The estimate for compound 3 lay 1.2-fold (0.06 log units) above the measured number; low and high end bracket the measured number.
By their numbers in this assay, from the lowest: compounds 2 and 3 (each within the scatter of the next); then compound 1.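

In this assay putting 2-fluorophenyl in place of 3-fluorophenyl gives a 1.2-fold higher number from compound 2 to compound 3 (0.07 log units; within the scatter) and so shows no difference between these two fluorine placements on the ring. Both fluorophenyl compounds stand apart from the 4-methoxyphenyl compound, as a 2.6-fold lower number from compound 1 to compound 3 (0.41 log units; beyond the scatter) now joins the earlier step. Nothing available here explains this result. As far as these compounds go, it stays open whether the kind of group or its place on the ring matters more, since compound 1 differs from compound 2 and compound 3 in both. Plain phenyl or 4-fluorophenyl could help separate the two.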